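Swapping Bromine for Fluorine in a Hydroxamic Acid Series

The source may report more compounds than this note shows. Statements on the series, on what has been measured and on what is new or still open speak of the compounds shown alone.

Three compounds have been measured in an assay on Sf9 cells for inhibition of protein deacetylase HDAC6 (Homo sapiens), read by fluorescence, with a stated time of 40 min; a lower number here means a stronger inhibitor, a higher number a weaker inhibitor:

Compound 1 `Cc1ccc(-n2nc(-c3ccccc3)nc2CNc2ccc(C(=O)NO)cc2)cc1`: 310 nM
Compound 2 `O=C(NO)c1ccc(NCc2nc(-c3ccc(Cl)cc3)nn2-c2ccccc2)cc1`: 181 nM
Compound 3 `O=C(NO)c1ccc(NCc2nc(-c3ccccc3)nn2-c2ccc(Br)cc2)cc1`: 1730 nM

Compound 3 gives the highest number of the three. The step of a 5.6-fold higher number from compound 1 to compound 3 (0.75 log units; beyond the scatter) lies beyond the scatter, and compound 2 sits lower still, so compound 3 is the weakest inhibitor shown. Compound 4 `O=C(NO)c1ccc(NCc2nc(-c3ccccc3)nn2-c2ccc(F)cc2)cc1` differs from compound 3 by fluoro in place of bromo on an aromatic carbon. Going by the values given here, only one measured step touches this position, a 5.6-fold higher number from compound 1 to compound 3 (0.75 log units; beyond the scatter), where methyl gave way to bromo and the number rose. Fluoro is a different group from both, so that step gives a hint rather than a rule: the bromo compound sits at the weak end, leaving room for a modest gain. Compound 4 is therefore expected to come in somewhat stronger than compound 3, a step of a 1.9-fold lower number from compound 3 to compound 4 (0.28 log units; within the scatter), with an estimated 900 nM in this assay, ranging from 350 nM to 2500 nM.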

Compound 4, half-maximal inhibitory concentration: 274 nM
Estimate against measurement, compound 4: 3.3-fold (0.52 log units) above, outside the stated range (below it).
By their numbers in this assay, from the lowest: compounds 2, 4 and 1 (each within the scatter of the next); then compound 3.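

In this assay, fluoro in place of bromo gives a 6.3-fold lower number from compound 3 to compound 4 (0.80 log units; beyond the scatter) and so shows that the weak result of compound 3 does not extend to every halogen at this position. Fluoro in place of methyl gives a 1.1-fold lower number from compound 1 to compound 4 (0.05 log units; within the scatter) and leaves these two groups indistinguishable here, so among the three groups tried on this ring, only bromo stands apart. Nothing shown here accounts for the bromo result. Going by these compounds, whether an amine or a methoxy group at this position would match fluoro and methyl or fall with bromo remains open.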